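Triazole to pyrazole swap on the aryl ring: stability notes

This account rests on a few compounds, and the source may have more. Where it says the series, first, only, none or still open, it means among the compounds named here.

Compound 1 `COc1ccc(-c2cc(-c3ccc(S(N)(=O)=O)cc3)cnc2N)cn1`: in an in vitro ADME assay on microsomes from liver (Homo sapiens) for metabolic stability (on this read-out lower numbers stand for a shorter-lived compound and higher numbers for a longer-lived compound), compound 1 gives > 4.16 h, a limit of the assay.
Compound 2 `COc1ccc(-c2cc(-c3ccc(NS(C)(=O)=O)cc3)cnc2N)cn1`: in this assay compound 2 gives > 4.16 h, also a limit.
Compound 3 `COc1ccc(-c2cc(-c3ccc(-n4cncn4)cc3)cnc2N)cn1`: in this assay compound 3 gives 3.5 h.

For the measured compounds named here, compound 3 thus carries the only number in the set; the other two values sit at the limit of > 4.16 h in this assay, at which 2 of the 3 values shown sit. The readable steps both run into compound 3: an at least 1.1-fold lower number from compound 1 to compound 3 (0.07 log units; that floor lies within the scatter) and an at least 1.1-fold lower number from compound 2 to compound 3 (0.07 log units; that floor lies within the scatter), each with a floor inside the scatter. Compound 4 `COc1ccc(-c2cc(-c3ccc(-n4cccn4)cc3)cnc2N)cn1` differs from compound 3 by 1H-pyrazol-1-yl in place of 1H-1,2,4-triazol-1-yl on an aromatic carbon. Going by the values given here, neither measured step exchanges one azole for another, so no direct precedent exists; both steps onto compound 3 stayed small, and no movement beyond the scatter is expected for this assay, a 1.2-fold lower number from compound 3 to compound 4 (0.07 log units; within the scatter). Compound 4 is estimated at 3 h, between 1.5 h and 4.5 h.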

Compound 4, half-life: 3.38 h
Beside the measured number, compound 4's estimate is 1.1-fold (0.05 log units) below it, and the stated range covers the measured number.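

Exchanging one azole for another on this aromatic carbon gives a 1.0-fold lower number from compound 3 to compound 4 (0.02 log units; within the scatter) in this assay. The steps from the two non-azole groups show only floors: an at least 1.2-fold lower number from compound 2 to compound 4 (0.09 log units; that floor lies within the scatter) and an at least 1.2-fold lower number from compound 1 to compound 4 (0.09 log units; that floor lies within the scatter). Both floors rest on a limit of the assay, not a number: the limit of > 4.16 h in this assay, at which 2 of the 4 values shown sit.

On these data alone, how far the azoles truly lie from the methanesulfonamido and sulfamoyl compounds stays open. Also open, as far as these compounds go, is whether a different group on this carbon, such as a carboxylic acid or a primary amine, would shift the half-life beyond the scatter.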